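Notes on the aryl hydrazone variation of the series

The source may hold more compounds than are shown below. What is called first, only, known or untested is meant among the compounds shown, and "the series" means these compounds.

The three measured compounds share one core and differ only in the aryl group on the carbon with a double bond to nitrogen. Compound 1 `CN(C)CCn1cnnc1-c1cc(Oc2ccc(NC(=O)N/N=C/c3ccc(F)cc3Cl)cc2F)ccn1` gives in a functional assay on NCI-H460 cells (Homo sapiens) for cytotoxicity, read by MTT assay, with a stated time of 72 h (a lower number here means a stronger inhibitor, a higher number a weaker inhibitor), a value of 720 nM. Compound 2 `CN(C)CCn1cnnc1-c1cc(Oc2ccc(NC(=O)N/N=C/c3ccc(Cl)cc3)cc2F)ccn1` gives 320 nM, and compound 3 `CN(C)CCn1cnnc1-c1cc(Oc2ccc(NC(=O)N/N=C/c3cc(Br)c(O)c(Br)c3)cc2F)ccn1` gives 3760 nM. Compound 3 stands highest of the three: it is weaker than compound 1 by a 5.2-fold higher number from compound 1 to compound 3 (0.72 log units; beyond the scatter) and weaker than compound 2 by a 12-fold higher number from compound 2 to compound 3 (1.07 log units; beyond the scatter), while the step of a 2.3-fold lower number from compound 1 to compound 2 (0.35 log units; beyond the scatter) is modest.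

Compound 4 `COc1ccc(/C=N/NC(=O)Nc2ccc(Oc3ccnc(-c4nncn4CCN(C)C)c3)c(F)c2)cc1O` is compound 3 with the change (3-hydroxy-4-methoxyphenyl in place of 3,5-dibromo-4-hydroxyphenyl on a carbon with a double bond to nitrogen). Within the data shown here, no measured step removes the two bromines or brings in a methoxy group, so only indirect steps bear on it: a 5.2-fold higher number from compound 1 to compound 3 (0.72 log units; beyond the scatter) and a 12-fold higher number from compound 2 to compound 3 (1.07 log units; beyond the scatter), which both show the 3,5-dibromo-4-hydroxyphenyl as the weakest aryl group in the set. Leaving that group is expected to lower the number, but the entering 3-hydroxy-4-methoxyphenyl keeps the hydroxy group and is no halophenyl, so the expected step of a 2.5-fold lower number from compound 3 to compound 4 (0.40 log units; beyond the scatter) is taken as modest and uncertain. Compound 4 is estimated at 1500 nM, with a range from 500 nM to 5000 nM.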

Compound 4, half-maximal inhibitory concentration: 620 nM
Beside the measured number, compound 4's estimate is 2.4-fold (0.38 log units) above it; measured number inside the range.
By their numbers in this assay, from the lowest: compounds 2, 4 and 1 (each within the scatter of the next, the first and the last beyond it); then compound 3.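

Compound 3's high number does not follow from having a hydroxy group on the aryl ring: 3-hydroxy-4-methoxyphenyl also carries one, yet in this assay there is a 6.1-fold lower number from compound 3 to compound 4 (0.78 log units; beyond the scatter). An aryl group with no halogen is also accommodated on the carbon with a double bond to nitrogen, since a 1.9-fold higher number from compound 2 to compound 4 (0.29 log units; within the scatter) and a 1.2-fold lower number from compound 1 to compound 4 (0.06 log units; within the scatter), which leaves 3-hydroxy-4-methoxyphenyl not separable from 4-chlorophenyl or 2-chloro-4-fluorophenyl here. No available measurement accounts for these differences.

Loss of the two bromines and gain of the methoxy group arrive together in one step, so their shares remain open; a 4-hydroxyphenyl or a 3,5-dibromo-4-methoxyphenyl would separate them. Also open, going by these compounds, is how an aryl group bearing an amine or a carboxylic acid would fall in this assay's range.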